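Cytotoxicity of a nitro-sulfone amide series in liver cells

The compounds below may be only part of what the source reports. "The series", "measured", "known", "first", "only" and "open" are said of these compounds alone.

Compound 1 `CN(Cc1cccc(F)c1)C(=O)CCCNC(=O)c1ccc(S(C)(=O)=O)c([N+](=O)[O-])c1` was tested in an ADME assay on HepG2 cells (Homo sapiens) for cytotoxicity, read by CellTiter-Glo and ATP content, with a stated time of 72 h; on this read-out higher numbers stand for an effect only at larger amounts of compound and lower numbers for an effect already at smaller amounts. In this assay compound 1 gives only a limit, > 27000 nM. Compound 3 `CN1CCN(C(=O)C2CCN(C(=O)c3ccc(S(C)(=O)=O)c([N+](=O)[O-])c3)CC2)CC1` likewise gives only a limit in this assay, > 27000 nM. Compound 2 `CS(=O)(=O)c1ccc(C(=O)NCC(=O)N(Cc2ccccc2)Cc2ccccc2)cc1[N+](=O)[O-]` gives 11900 nM in this assay. Compound 1 therefore sits at the limit of > 27000 nM in this assay, at which 2 of the 3 values shown sit. Compound 4 `CS(=O)(=O)c1ccc(C(=O)NCCCC(=O)N2Cc3ccccc3C2)cc1[N+](=O)[O-]` differs from compound 1 by a group of 9 heavy atoms (8 carbon, 1 nitrogen; one five-membered non-aromatic ring with 1 hetero atom, one six-membered aromatic ring of carbon only) in place of a group of 10 heavy atoms (8 carbon, 1 nitrogen, 1 fluorine; one six-membered aromatic ring of carbon only), on a carbonyl carbon. Among the measured compounds shown here, no measured pair of compounds shares this change, so its size cannot be read from the data. Compound 4 is expected to remain near the same limit, with an estimated step of an at least 1.1-fold lower number from compound 1 to compound 4 (0.05 log units; that floor lies within the scatter) not beyond the scatter. The estimate for compound 4 is 24000 nM, between 9000 nM and 27000 nM.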

Compound 4, half-maximal effective concentration: > 27000 nM
Compound 4: no number, only a limit (the forecaster's own chance of this, stated with the estimate: 65%); middle value at least 1.1-fold (0.05 log units) from the limit.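

Among the compounds shown here, compound 1 and compound 4 each give only a limit in this assay, so no step between them can be read. The compounds shown leave open whether replacing the (3-fluorobenzyl)(methyl)amino group changes the read-out at all.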